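Dropping the Chloro Group: From Compound 2 to Compound 3

A few compounds are considered here, and "the series" means these few. Any claim that something is new, unique, unknown or untested is made for them only; others in the source may bear on it.

For the measured compounds named here, compound 2 `O=C(/C=C/c1ccc(Cl)cc1)c1ccc(NC(=S)Nc2ccc(Cl)cc2)cc1` gives 7.59 umol/kg in a functional assay on the whole organism (Abdomen, strain Swiss) with Mus musculus as the target, with a stated time of 30 min (a higher number here means that more compound is needed for the effect, a lower number that less compound is needed), the lowest of the two numbers measured so far. Its nearest neighbour, compound 1 `Cc1ccc(/C=C/C(=O)c2ccc(NC(=S)Nc3ccc(Cl)cc3)cc2)cc1`, gives 13.1 umol/kg in this assay, and the step between them, a 1.7-fold lower number from compound 1 to compound 2 (0.24 log units; within the scatter), lies within the scatter. Compound 3 `O=C(/C=C/c1ccccc1)c1ccc(NC(=S)Nc2ccc(Cl)cc2)cc1` differs from compound 2 by hydrogen in place of chloro on an aromatic carbon. Going by the values given here, the only measured step at that same aromatic carbon stayed within the scatter, so no step beyond the scatter is expected here either. Compound 3 is therefore estimated at 10 umol/kg in this assay, between 4 umol/kg and 25 umol/kg, an expected step of a 1.3-fold higher number from compound 2 to compound 3 (0.12 log units; within the scatter).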

Compound 3, dose for 50% inhibition: 3.03 umol/kg
Beside the measured number, compound 3's estimate is 3.3-fold (0.52 log units) above it; measured number below the stated range.
By their numbers in this assay, from the lowest: compound 3; then compounds 2 and 1 (each within the scatter of the next).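

In this assay, this aromatic carbon, para to a large group, now shows a step beyond the scatter: hydrogen in place of chloro gives a 2.5-fold lower number from compound 2 to compound 3 (0.40 log units; beyond the scatter) and hydrogen in place of methyl gives a 4.3-fold lower number from compound 1 to compound 3 (0.64 log units; beyond the scatter). Among these three compounds, the two substituted ones lie within the scatter of each other, and hydrogen gives the lowest number. Nothing available explains this difference. The compounds shown leave open how a methoxy group or an amine at this carbon would compare with hydrogen.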